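The source may hold more compounds than are shown below. What is called first, only, known or untested is meant among the compounds shown, and "the series" means these compounds.

Compound 3 `COc1ccc(N2C(=O)/C(=C/c3ccc(OCc4ccc(C(=O)O)cc4)cc3)SC2=S)cc1` stands at the edge of the numbers shown. In an assay on isolated protein for inhibition of Apoptosis regulator Bcl-2 (Homo sapiens), read by fluorescence polarization (on this read-out higher numbers stand for weaker inhibition and lower numbers for stronger inhibition), compound 3 gives > 10000 nM, which is a limit of the assay rather than a number. Compound 4 `O=C(O)c1ccc(COc2ccc(/C=C3\SC(=S)N(c4ccc(Br)cc4)C3=O)cc2)cc1` differs from it only by bromo in place of methoxy on an aromatic carbon. Within the data shown here, the single measured step, a 1.3-fold lower number from compound 1 to compound 2 (0.12 log units; within the scatter), concerns a different change on the same ring: compound 1 `COc1ccccc1N1C(=O)/C(=C/c2ccc(OCC(=O)Nc3ccc(C(=O)O)cc3)cc2)SC1=S` gives 10000 nM and compound 2 `Cc1cccc(C)c1N1C(=O)/C(=C/c2ccc(OCC(=O)Nc3ccc(C(=O)O)cc3)cc2)SC1=S` gives 7600 nM. That step is within the scatter and does not bear directly on a bromo for methoxy exchange. Compound 3 sits at the limit of > 10000 nM in this assay, at which 1 of the 3 values shown sits, so there is no room for a weaker reading. Compound 4 is therefore expected to show a step that the limit leaves unreadable from compound 3 to compound 4, most likely another limit. The estimate for compound 4 in this assay is 12000 nM, with a range of 5000 nM to 30000 nM.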

Compound 4, inhibition constant: 610 nM
Compound 4: middle estimate off by 20-fold (1.29 log units), on the high side, and the stated range ends above it.
By their numbers in this assay, from the lowest: compound 4; then compounds 2 and 1 (each within the scatter of the next).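

In this assay, changing 4-methoxyphenyl to 4-bromophenyl gives an at least 16-fold lower number from compound 3 to compound 4 (1.21 log units; beyond the scatter) and yields the first clearly sub-micromolar reading shown, so this position on the ring can strongly change the reading. The earlier change on the same ring, a 1.3-fold lower number from compound 1 to compound 2 (0.12 log units; within the scatter) and so gave no such sign. Compound 3 stands at a limit of the assay and not at a number: the limit of > 10000 nM in this assay, at which 1 of the 4 values shown sits. From the compounds shown here alone, whether chloro or nitrile in this place would read like bromo remains open, as does whether 4-bromophenyl would give a similar step with the longer amide linker of compound 1.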